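Methoxy in Place of Ethoxycarbonyl on the Amine Nitrogen

The compounds below may be only part of what the source reports. "The series", "measured", "known", "first", "only" and "open" are said of these compounds alone.

Measured so far, in an assay for inhibition of transient receptor potential cation channel subfamily V member 1 (Rattus norvegicus), with a stated time of 10 min; a lower number here means a stronger inhibitor, a higher number a weaker inhibitor:
compound 1, `CC(C)(C)c1ccc(CCC/N=C(\S)NCc2ccc(NS(C)(=O)=O)c(F)c2)cc1`, gives 2000 nM;
compound 2, `CS(=O)(=O)Nc1ccc(C/N=C(\S)NC(c2ccccc2)c2ccccc2)cc1F`, gives 2500 nM;
compound 3, `CCOC(=O)N/C(=N\Cc1ccc(NS(C)(=O)=O)c(F)c1)NCc1ccc(C(C)(C)C)cc1`, gives 6200 nM.

Compound 3 carries the highest of the three numbers in this assay; its gap to compound 2 and its wider gap to compound 1 both lie beyond the usual scatter. Compound 4, `CON/C(=N\Cc1ccc(NS(C)(=O)=O)c(F)c1)NCc1ccc(C(C)(C)C)cc1`, departs from compound 3 by one change: methoxy in place of ethoxycarbonyl on an amine nitrogen. Among the measured compounds shown here, no measured pair shows this change, so nothing fixes its size. The expectation is a step from compound 3 to compound 4 of a 1.6-fold lower number from compound 3 to compound 4 (0.19 log units; within the scatter), a slightly lower number, but not beyond the scatter. For compound 4 the estimate in this assay is 4000 nM, within a range from 1500 nM to 12000 nM.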

Compound 4, half-maximal inhibitory concentration: 3100 nM
Beside the measured number, compound 4's estimate is 1.3-fold (0.11 log units) above it, within the range that was stated.
By their numbers in this assay, from the lowest: compounds 1, 2, 4 and 3 (each within the scatter of the next, the first and the last beyond it).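

In this assay the exchange of ethoxycarbonyl for methoxy on this amine nitrogen gives a 2.0-fold lower number from compound 3 to compound 4 (0.30 log units; within the scatter) and so stays within the scatter. This position therefore accepts two quite different groups, one of 5 heavy atoms with a carbonyl and one of 2 heavy atoms without it, with no readable change in the number. Nothing shown accounts for this result.

As far as these compounds go, it remains open whether a hydroxy group, a nitrile or the bare amine on this nitrogen would read the same. From the compounds shown here alone, a longer alkoxy group such as ethoxy or benzyloxy is equally open.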